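Swapping a Trifluoromethylphenyl for Pyridinyl on a Thiourea

The source may hold more compounds than are shown below. What is called first, only, known or untested is meant among the compounds shown, and "the series" means these compounds.

Compound 1 `Cc1ccccc1CN1CCc2c(sc(NC(=O)c3ccccc3Cl)c2C(N)=O)C1` gives in a functional assay on HeLa cells (Homo sapiens) for antiproliferative activity, with a stated time of 24 h (on this read-out lower numbers stand for stronger inhibition and higher numbers for weaker inhibition), a limit of > 50000 nM rather than a number.
Compound 2 `NC(=O)c1c(NC(=O)c2ccccc2Cl)sc2c1CCN(C(=O)Nc1ccccc1Cl)C2` gives in this assay 45400 nM.
Compound 3 `NC(=O)c1c(NC(=O)c2ccccc2Cl)sc2c1CCN(C(=S)Nc1ccccc1C(F)(F)F)C2` gives in this assay 26700 nM.

Among the values shown, compound 3 holds the lowest number, but compound 2 sits within the usual scatter of it, so no order between the two can be claimed; the value of compound 1 is a limit and not a number. Going by the values given here, the only measured step that changes one place is an at least 1.1-fold lower number from compound 1 to compound 2 (0.04 log units; that floor lies within the scatter), a change on the ring amine that stays within the scatter. Compound 4 `NC(=O)c1c(NC(=O)c2ccccc2Cl)sc2c1CCN(C(=S)Nc1cccnc1)C2` differs from compound 3 in a different place: pyridin-3-yl in place of 2-(trifluoromethyl)phenyl on an amide-type nitrogen. Among the compounds with values here, no measured step touches this part of the molecule, so the expectation rests on the general weakness of all three compounds in this assay. The step is expected to be a 1.3-fold higher number from compound 3 to compound 4 (0.12 log units; within the scatter), that is, no change beyond the scatter, with some chance that only a limit is returned. Compound 4 is therefore estimated to give 35000 nM, with a range from 12000 nM to 60000 nM.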

Compound 4, half-maximal inhibitory concentration: > 50000 nM
Compound 4 was reported as a limit; the forecaster's own chance of this, stated with the estimate: 35%; middle value at least 1.4-fold (0.15 log units) away from the limit.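

The result for compound 4 in this assay is a limit and not a number, the same limit that compound 1 gave: the limit of > 50000 nM in this assay, at which 2 of the 4 values shown sit.

Going by these compounds alone, this is the first look at the group on the amide-type nitrogen of the thiocarbonyl, and pyridin-3-yl in place of 2-(trifluoromethyl)phenyl gives an at least 1.8-fold higher number from compound 3 to compound 4 (0.27 log units; that floor lies within the scatter); the true step may be larger than this floor. Changing the whole group on the amine nitrogen in the ring gives an at least 1.1-fold higher number from compound 2 to compound 4 (0.04 log units; that floor lies within the scatter), while the step between the two limits cannot be read.

From the compounds shown here alone, whether the pyridin-3-yl change moves the number at all stays open, as both floors lie within the scatter. A plain phenyl on this nitrogen would separate the loss of the trifluoromethyl from the entry of the ring nitrogen.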